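Carbamate aryl variation in the fatty-acid amide hydrolase series

A few compounds are considered here, and "the series" means these few. Any claim that something is new, unique, unknown or untested is made for them only; others in the source may bear on it.

Measured compounds:
compound 1, `CCCCOc1ccc(C(CC)NC(=O)Oc2ccccc2F)cc1`, 7.7 nM
compound 2, `CCCCOc1ccc(C(CC)NC(=O)Oc2cccc(N(C)C)c2)cc1`, 54 nM
compound 3, `CCCCOc1ccc(C(CC)NC(=O)Oc2ccc(OC)cc2)cc1`, 12 nM

In an assay on H4 cells for inhibition of Fatty-acid amide hydrolase 1 (Homo sapiens) (on this read-out higher numbers stand for weaker inhibition and lower numbers for stronger inhibition), compound 3 gives 12 nM, the second highest of the three numbers. Its step to compound 1 is small, a 1.6-fold higher number from compound 1 to compound 3 (0.19 log units; within the scatter), while its step from compound 2 is clear, a 4.5-fold lower number from compound 2 to compound 3 (0.65 log units; beyond the scatter); the largest gap in the set is a 7.0-fold higher number from compound 1 to compound 2 (0.85 log units; beyond the scatter).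

Compound 4, `CCCCOc1ccc(C(CC)NC(=O)Oc2ccccc2)cc1`, is not yet measured. It differs from compound 3 in one place: hydrogen in place of methoxy on an aromatic carbon. Among the measured compounds shown here, no measured step removes a substituent from the varied aromatic ring outright; the nearest analogy is the exchange of substituents, where compound 1 and compound 3 lie within the scatter of each other and only compound 2 stands apart. On that basis, with compound 3 at 12 nM and compound 1 at 7.7 nM, the expected step in this assay is a 1.2-fold lower number from compound 3 to compound 4 (0.08 log units; within the scatter), that is, no change beyond the scatter. Compound 4 is therefore estimated at 10 nM, with a range from 4 nM to 30 nM.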

Compound 4, half-maximal inhibitory concentration: 12 nM
For compound 4 the middle estimate is 1.2-fold (0.08 log units) below the measured one; low and high end bracket the measured number.
By their numbers in this assay, from the lowest: compounds 1, 3 and 4 (each within the scatter of the next); then compound 2.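

Compound 4 shows that the aromatic ring of the carbamate holds this level in this assay with no substituent at all: hydrogen in place of methoxy gives (no change at the digits printed from compound 3 to compound 4 (within the scatter)), and hydrogen in place of fluoro gives (a 1.6-fold higher number from compound 1 to compound 4 (0.19 log units; within the scatter)). Neither the methoxy of compound 3 nor the fluoro of compound 1 therefore separates from plain hydrogen. The dimethylamino group is the exception, since hydrogen in its place gives (a 4.5-fold lower number from compound 2 to compound 4 (0.65 log units; beyond the scatter)), so compound 2 is now set against an unsubstituted reference rather than only against other substituents.

Open, going by these compounds, is whether a carboxylic acid or a primary amine in the place of that methoxy would stay close to compound 4, and whether the dimethylamino result would hold with that group moved elsewhere on the ring. Nothing on hand explains why hydrogen, methoxy and fluoro read alike while dimethylamino does not.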